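From Methoxy to Methylcarbamoyl on a Shared Core

The source may hold more compounds than are shown below. What is called first, only, known or untested is meant among the compounds shown, and "the series" means these compounds.

Compound 2 `COc1cccc2c1CCC2c1ncc[nH]1` was tested in a functional assay on CHO cells for agonist activity at Alpha-1B adrenergic receptor (Homo sapiens), read by FLIPR and calcium flux; a higher number here means that more compound is needed for the effect, a lower number that less compound is needed. In this assay compound 2 gives > 10000 nM, which is a limit of the assay and not a number. Compound 1 `COc1c(C)ccc2c1CCC2c1ncc[nH]1` likewise gives > 10000 nM, again a limit. Compound 3 `CCS(=O)(=O)Nc1cccc(Cc2c[nH]cn2)c1` gives > 10000 nM, also a limit. Going by the values given here, the only measured step, a step that the two limits leave unreadable from compound 1 to compound 2, stays unreadable because both of its values sit at the limit of > 10000 nM in this assay, at which 3 of the 3 values shown sit. Compound 4 `CNC(=O)c1cccc2c1CCC2c1ncc[nH]1` differs from compound 2 by methylcarbamoyl in place of methoxy on an aromatic carbon. Among the compounds with values here, no measured step bears on this change, so no direction can be read from the data. Compound 4 is therefore expected to remain near the limit, with an estimated step that the limit leaves unreadable from compound 2 to compound 4. The estimate for compound 4 is 20000 nM, ranging from 3000 nM to 100000 nM.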

Compound 4, half-maximal effective concentration: > 10000 nM
Compound 4: a limit, no number; the forecaster's own chance of this, stated with the estimate: 80%; the middle value does not contradict the limit.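

Going by these compounds alone, compound 4 also stays at a limit of the assay, so no step from compound 2 to compound 4 can be read: the limit of > 10000 nM in this assay, at which 4 of the 4 values shown sit. The compounds shown leave open whether in this assay any change on the shared core would bring a value that can be read.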